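Isobutyl to sec-butyl on the amine nitrogen: expected outcome

This account rests on a few compounds, and the source may have more. Where it says the series, first, only, none or still open, it means among the compounds named here.

The series is followed in an ADME assay on EA.hy 926 cells (Homo sapiens) for inhibition, read by MTT assay, with a stated time of 72 h; a lower number here means a stronger inhibitor, a higher number a weaker inhibitor. Compound 3 `COc1cc(/C=C/C(=O)/C=C(/C=C/c2ccc(O)c(OC)c2)NCC(C)C)ccc1O` reaches only a limit there, > 25000 nM. Compound 1 `CCC(C)NC(=C\C(=O)/C=C/c1ccc(O)c(OC)c1)/C=C/c1ccc(O)c(OC)c1` carries the change sec-butyl in place of isobutyl on an amine nitrogen and likewise reaches only a limit, > 25000 nM. The step that the two limits leave unreadable from compound 3 to compound 1 cannot be read because the limit of > 25000 nM in this assay, at which 3 of the 3 values shown sit, covers both of its ends.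

Compound 2 `COc1cc(/C=C/C(=O)/C=C(/C=C/c2ccc(OC(C)=O)c(OC)c2)NCC(C)C)ccc1OC(C)=O` belongs to a different core; the difference between the two cores is not broken down here. In this assay compound 2 also reaches only a limit, > 25000 nM.

Compound 4 `CCC(C)NC(=C\C(=O)/C=C/c1ccc(OC(C)=O)c(OC)c1)/C=C/c1ccc(OC(C)=O)c(OC)c1` is not yet measured. It differs from compound 2 by sec-butyl in place of isobutyl on an amine nitrogen, which is the same change that leads from compound 3 to compound 1, the place being the same word for word in both pairs. Among the compounds shown this change occurs twice, and its one measured instance gives no readable size.

All three measured values sit at the limit, so nothing in the data separates the two alkyl groups on the amine nitrogen. The step that the limit leaves unreadable from compound 2 to compound 4 is expected to be flat, resting on the unreadable a step that the two limits leave unreadable from compound 3 to compound 1 and on (the limit of > 25000 nM in this assay, at which 3 of the 3 values shown sit). For compound 4 the estimate is 40000 nM, with an expected range from 25000 nM to 100000 nM, and the expectation is that this assay will again report only a limit rather than a number.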

Compound 4, half-maximal inhibitory concentration: > 25000 nM
Compound 4 gave a limit, no number (the forecaster's own chance of this, stated with the estimate: 85%); the middle value is on the limit's open side.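

In this assay compound 4 gives > 25000 nM, a limit and not a number. No new step can be read from compound 2 to compound 4, because both ends sit at the same limit: the limit of > 25000 nM in this assay, at which 4 of the 4 values shown sit.

The compounds shown leave open whether sec-butyl and isobutyl on the amine nitrogen differ at all in this assay, and whether either core would give a readable number.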